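One Aryl Swap and an Expected Flat Cytotoxicity Reading

The compounds below may be only part of what the source reports. "The series", "measured", "known", "first", "only" and "open" are said of these compounds alone.

Compound 1 `Cc1ccccc1-c1nn(-c2ccccc2Cl)cc1CNCCN1CCN(C)CC1` was examined in an ADME assay on Huh-7 cells (Homo sapiens) for cytotoxicity; on this read-out higher numbers stand for lower toxicity in this test and lower numbers for higher toxicity in this test. In this assay compound 1 gives > 20000 nM, which is a limit of the assay rather than a number. Compound 2 `CN1CCN(CCNCc2cn(-c3ccc(F)cc3F)nc2-c2ccccc2)CC1` gives > 20000 nM, likewise a limit. Compound 3 `Cc1c(CNCCN2CCN(C)CC2)c(-c2ccccc2)nn1-c1ccc(F)cc1` gives > 20000 nM, again a limit. All three measured values thus sit at the limit of > 20000 nM in this assay, at which 3 of the 3 values shown sit. Compound 4 `Cc1ccccc1-c1nn(-c2ccc(F)cc2)cc1CNCCN1CCN(C)CC1` has not yet been measured in this assay. It differs from compound 1 by 4-fluorophenyl in place of 2-chlorophenyl on an aromatic nitrogen. With compounds 1, 2 and 3 all at the limit, no step beyond the usual scatter is expected from this change. The half-maximal cytotoxic concentration of compound 4 is therefore estimated at 20000 nM, within a range from 10000 nM to 40000 nM. The expected step of a number no higher from compound 1 to compound 4 (the limit leaves the size open) is essentially none.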

Compound 4, half-maximal cytotoxic concentration: > 20000 nM
Compound 4: a limit, no number; the forecaster's own chance of this, stated with the estimate: 85%; the middle value sits exactly at the limit.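

In this assay compound 4 gives > 20000 nM, which is a limit of the assay. For the compounds shown here, compound 1 also stands at a limit, and no step between compound 1 and compound 4 can be read. The compounds shown leave open whether 4-fluorophenyl in place of 2-chlorophenyl changes this read-out at all.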